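This account rests on a few compounds, and the source may have more. Where it says the series, first, only, none or still open, it means among the compounds named here.

Measured compounds:
compound 1 `CC(C)c1ccc(-n2cc(-c3cn([C@H]4C[C@H](O)[C@@H](CO)O4)c(=O)[nH]c3=O)nn2)cc1`: 22000 nM
compound 2 `O=c1[nH]c(=O)n([C@H]2C[C@H](O)[C@@H](CO)O2)cc1-c1cn(-c2ccc(Cl)cc2)nn1`: 13000 nM
compound 3 `O=c1[nH]c(=O)n([C@H]2C[C@H](O)[C@@H](CO)O2)cc1-c1cn(-c2ccc(OC(F)(F)F)cc2)nn1`: 35000 nM

In an ADME assay on CCRF-CEM cells (Homo sapiens) for cytotoxicity, read by cell counting, with a stated time of 3 days (a higher number here means a weaker inhibitor, a lower number a stronger inhibitor), compound 3 gives 35000 nM, a number close to that of compound 1 (a 1.6-fold higher number from compound 1 to compound 3 (0.20 log units; within the scatter)) and further from that of compound 2 (a 2.7-fold higher number from compound 2 to compound 3 (0.43 log units; beyond the scatter)). Compound 4 `O=c1[nH]c(=O)n([C@H]2C[C@H](O)[C@@H](CO)O2)cc1-c1cn(-c2ccc(Oc3ccccc3)cc2)nn1` differs from compound 3 in one place: phenyl in place of trifluoromethyl on an oxygen on an aromatic ring. Going by the values given here, no measured step changes the group on that oxygen; the three steps that exist swap the whole substituent on the aromatic carbon, and they are small: a 1.7-fold lower number from compound 1 to compound 2 (0.23 log units; within the scatter), a 1.6-fold higher number from compound 1 to compound 3 (0.20 log units; within the scatter) and a 2.7-fold higher number from compound 2 to compound 3 (0.43 log units; beyond the scatter). On that evidence the change to a phenoxy group is expected to move this assay little, and compound 4 is expected to give about 30000 nM, between 12000 nM and 80000 nM. That estimate means a step of a 1.2-fold lower number from compound 3 to compound 4 (0.07 log units; within the scatter), expected to stay within the scatter.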

Compound 4, half-maximal inhibitory concentration: 800 nM
Beside the measured number, compound 4's estimate is 38-fold (1.57 log units) above it, outside the stated range (below it).
By their numbers in this assay, from the lowest: compound 4; then compounds 2, 1 and 3 (each within the scatter of the next, the first and the last beyond it).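

In this assay the group on this aromatic carbon proves far from indifferent, since phenyl in place of trifluoromethyl on the oxygen gives (a 44-fold lower number from compound 3 to compound 4 (1.64 log units; beyond the scatter)), a change much larger than any step among compounds 1, 2 and 3. Phenoxy also stands well apart from chloro (a 16-fold lower number from compound 2 to compound 4 (1.21 log units; beyond the scatter)) and from isopropyl (a 28-fold lower number from compound 1 to compound 4 (1.44 log units; beyond the scatter)). Compound 3 carries the same oxygen, so that atom alone does not accompany the large drop, and no available evidence explains it. From the compounds shown here alone, whether the oxygen link is needed remains open: a directly attached phenyl, a benzyl group or an anilino amine could separate the ring from its link.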